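The compounds below may be only part of what the source reports. "The series", "measured", "known", "first", "only" and "open" are said of these compounds alone.

Working notes on the series, following the step from compound 1 (`CC(C)n1cnc2c(NCc3ccc(O)cc3)nc(NCCCO)nc21`) to compound 4 (`CC(C)C(CO)Nc1nc(NCc2ccc(O)cc2)c2ncn(C(C)C)c2n1`). In a functional assay on CCRF-CEM cells (Homo sapiens) for cytotoxicity (a lower number here means a stronger inhibitor, a higher number a weaker inhibitor), compound 1 gives 18200 nM and sits level with compound 2 (`CC(C)n1cnc2c(NCc3cccc(O)c3)nc(NCCCO)nc21`) at 17600 nM on these numbers. Among the measured compounds shown here, compound 3 (`CC(C)C(CO)Nc1nc(NCc2ccccc2O)c2ncn(C(C)C)c2n1`) reads lower at 4400 nM and holds the lowest of the three numbers so far.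

The change at issue (1-(hydroxymethyl)-2-methylpropyl in place of 3-hydroxypropyl on a nitrogen on an aromatic ring) puts 1-(hydroxymethyl)-2-methylpropyl in place of 3-hydroxypropyl on a nitrogen on an aromatic ring. For the measured compounds named here, no measured single-place step isolates this change. Going by the values given here, the one such step available is a 1.0-fold lower number from compound 1 to compound 2 (0.01 log units; within the scatter) with 3-hydroxyphenyl in place of 4-hydroxyphenyl, and it lies within the scatter. Among the compounds with values here, compound 3 carries the same 1-(hydroxymethyl)-2-methylpropyl as compound 4 but places its hydroxyl differently on the phenyl ring, and no step covers that placing. The expectation therefore rests on compound 3 at 4400 nM as an indirect guide, with the flat step a 1.0-fold lower number from compound 1 to compound 2 (0.01 log units; within the scatter) as the only support for carrying it over.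

A lower number is expected in this assay with an estimated step of a 3.6-fold lower number from compound 1 to compound 4 (0.56 log units; beyond the scatter) that lies beyond the scatter. For compound 4 the expected value is 5000 nM with an estimated range of 2200 nM to 12000 nM for now.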

Compound 4, half-maximal inhibitory concentration: 5300 nM
Compound 4: middle estimate off by 1.1-fold (0.03 log units), on the low side; the measured number falls inside the stated range.
By their numbers in this assay, from the lowest: compounds 3 and 4 (each within the scatter of the next); then compounds 2 and 1 (each within the scatter of the next).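

In this assay, 1-(hydroxymethyl)-2-methylpropyl in place of 3-hydroxypropyl on a nitrogen on an aromatic ring now has a direct reading with the 4-hydroxyphenyl held constant: a 3.4-fold lower number from compound 1 to compound 4 (0.54 log units; beyond the scatter), a modest step but the only one among the compounds shown that lies beyond the scatter. The hydroxyl placing, the other point left uncovered before, also gains a reading under the new chain, with 4-hydroxyphenyl in place of 2-hydroxyphenyl giving a 1.2-fold higher number from compound 3 to compound 4 (0.08 log units; within the scatter); this is flat, as is a 1.0-fold lower number from compound 1 to compound 2 (0.01 log units; within the scatter) under 3-hydroxypropyl, so among these four compounds the number follows the chain on the nitrogen and not the hydroxyl placing on the phenyl ring, and nothing on hand gives a reason for the chain step.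

One swap cannot separate the branching of 1-(hydroxymethyl)-2-methylpropyl from its larger size, so a longer unbranched chain ending in a hydroxyl, or the same branched chain ending in a primary amine, would be needed to tell what carries the step. On these data alone, it also stays open whether the hydroxyl itself matters on the phenyl ring, which a methoxy group or an unsubstituted phenyl would test.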